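Cytotoxicity notes: benzoyl to benzyl on the sugar side chain

The source may hold more compounds than are shown below. What is called first, only, known or untested is meant among the compounds shown, and "the series" means these compounds.

Compound 1 `Cc1cn([C@@H]2O[C@H](CO)[C@@]3(OS(=O)(=O)C=C3NC(=O)NC(=O)c3ccccc3)[C@H]2O[Si](C)(C)C(C)(C)C)c(=O)n(C)c1=O`: 20000 nM
Compound 2 `Cc1cn([C@@H]2O[C@H](COC(=O)c3ccccc3)[C@@]3(OS(=O)(=O)C=C3NC(=O)NC(=O)c3ccccc3)[C@H]2O[Si](C)(C)C(C)(C)C)c(=O)n(C)c1=O`: >= 5000 nM

In an ADME assay on HEL cells (Homo sapiens) for cytotoxicity, with a stated time of 3 days (a higher number here means that more compound is tolerated, a lower number that less compound is tolerated), compound 1 gives 20000 nM. For compound 2 only a limit is reported, >= 5000 nM. The step that the limit leaves unreadable from compound 1 to compound 2 is therefore unreadable because of the limit of >= 5000 nM in this assay, at which 1 of the 2 values shown sits. Compound 3 `Cc1cn([C@@H]2O[C@H](COCc3ccccc3)[C@@]3(OS(=O)(=O)C=C3NC(=O)NC(=O)c3ccccc3)[C@H]2O[Si](C)(C)C(C)(C)C)c(=O)n(C)c1=O` is not yet measured; it differs from compound 2 by benzyl in place of benzoyl on an oxygen on a saturated carbon. Among the measured compounds shown here, no measured step covers this change, and compound 2 itself stands only at a limit, so the expectation rests on compound 2 sitting no lower than its limit. Compound 3 is expected at 15000 nM, range 5000 nM to 50000 nM. The step expected is a step that the limit leaves unreadable from compound 2 to compound 3, within the scatter.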

Compound 3, minimum cytotoxic concentration: > 50000 nM
Compound 3: no number, only a limit (the forecaster's own chance of this, stated with the estimate: 50%); at least 3.3-fold (0.52 log units) between middle value and limit.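

Among the compounds shown here, on this oxygen on a saturated carbon, benzyl in place of hydrogen gives an at least 2.5-fold higher number from compound 1 to compound 3 (0.39 log units; beyond the scatter) in this assay, the first readable step at this position. The value of compound 3, > 50000 nM, is a limit. The steps that touch compound 2 cannot be read, so benzyl and benzoyl cannot be ranked here.

Still open, going by these compounds, is how far the tolerated concentration of compound 3 lies past its limit. Also open, on these data alone, is whether a phenethyl ether, or a benzyl carrying an amine or a carboxylic acid, would give a readable value in this assay.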